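The source may report more compounds than this note shows. Statements on the series, on what has been measured and on what is new or still open speak of the compounds shown alone.

Compound 1 `Oc1ccc(-c2cc(-c3ccccc3O)cc(-c3cccc(O)c3)n2)cc1`: 4850 nM in a functional assay on HCT-15 cells (Homo sapiens) for cytotoxicity, read by CCK-8 assay, with a stated time of 4 days; a lower number here means a stronger inhibitor, a higher number a weaker inhibitor
Compound 2 `Oc1cccc(-c2cc(-c3cccc(O)c3)nc(-c3ccccc3O)c2)c1`: > 50000 nM in this assay, a limit only

Compound 2 stands at the limit of > 50000 nM in this assay, at which 1 of the 2 values shown sits, so it gives no number, only a limit, and sits at the weak end of the two values shown. Compound 1 gives a real number, 4850 nM, in this assay. Compound 3 `Oc1ccc(-c2cc(-c3cccc(O)c3)cc(-c3cccc(O)c3)n2)cc1` differs from compound 2 by 4-hydroxyphenyl in place of 2-hydroxyphenyl on an aromatic carbon, next to the ring nitrogen. Among the compounds with values here, no step between measured compounds is known, so the size of the change must be guessed. Since compound 1, which also carries a 4-hydroxyphenyl, gives 4850 nM, a gain beyond the scatter is expected, though compound 1 differs from compound 3 in more than this one place. Compound 3 is therefore estimated at 15000 nM, between 4000 nM and 60000 nM. That estimate would mean an expected step of an at least 3.3-fold lower number from compound 2 to compound 3 (0.52 log units; beyond the scatter).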

Compound 3, half-maximal inhibitory concentration: 3090 nM
Compound 3: the middle estimate sits 4.9-fold (0.69 log units) above what was measured; the whole stated range lies above it.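

In this assay, 4-hydroxyphenyl in place of 2-hydroxyphenyl on the aromatic carbon next to the ring nitrogen gives an at least 16-fold lower number from compound 2 to compound 3 (1.20 log units; beyond the scatter), which shows that the choice between these two groups matters greatly at this position. From the compounds shown here alone, compound 2 gives only a limit, so the full size of this step stays unknown: the limit of > 50000 nM in this assay, at which 1 of the 3 values shown sits. At another aromatic carbon, by contrast, 3-hydroxyphenyl in place of 2-hydroxyphenyl gives a 1.6-fold lower number from compound 1 to compound 3 (0.20 log units; within the scatter), so a 2-hydroxyphenyl on the core does not by itself go with the loss seen in compound 2.

Going by these compounds, it remains open whether 3-hydroxyphenyl at the position next to the ring nitrogen would match 4-hydroxyphenyl there. The compounds shown also do not tell whether the hydroxyl itself is needed, as a plain phenyl, a 4-methoxyphenyl or a 4-aminophenyl at this position would show.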